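The source may hold more compounds than are shown below. What is called first, only, known or untested is meant among the compounds shown, and "the series" means these compounds.

Measured compounds:
compound 1 `C#CCOc1ccc(/C=C/C(=O)c2cccc(C)c2)cc1OC`: 1800 nM
compound 2 `C#CCOc1ccc(/C=C/C(=O)c2ccc(-n3ccnc3)cc2)cc1OC`: 1410 nM
compound 3 `C#CCOc1ccc(/C=C/C(=O)c2ccc(C(C)C)cc2)cc1CC=C`: 2840 nM

All three were run in a functional assay on U-87MG ATCC cells for cytotoxicity against U-87 MG (Homo sapiens), with a stated time of 72 h; on this read-out higher numbers stand for weaker inhibition and lower numbers for stronger inhibition. In this assay compound 1 gives 1800 nM, compound 2 gives 1410 nM and compound 3 gives 2840 nM. The three numbers lie close together: the gap from compound 1 to compound 2 and the gap from compound 1 to compound 3 are both within the usual scatter, so no ordering among them can be read from these values. Compound 1 therefore sits in the middle of a narrow cluster rather than at either end of a real spread.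

The next compound, compound 4 `C#CCOc1ccc(/C=C/C(=O)c2cccc(OC)c2)cc1OC`, is not yet measured. It differs from compound 1 in one place: methoxy in place of methyl on an aromatic carbon. For the measured compounds named here, no pair of measured compounds shows a change of this kind, so there is no measured step to lean on. Given how tightly the three measured values sit, the expectation for compound 4 is a step from compound 1 that stays within the scatter, with no clear direction, estimated as a 1.1-fold higher number from compound 1 to compound 4 (0.02 log units; within the scatter). Compound 4 is expected to give about 1900 nM, with a likely range from 900 nM to 4000 nM.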

Compound 4, half-maximal inhibitory concentration: 1460 nM
For compound 4 the middle estimate is 1.3-fold (0.11 log units) above the measured one, within the range that was stated.
By their numbers in this assay, from the lowest: compounds 2, 4, 1 and 3 (each within the scatter of the next).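

For the compounds shown here, this is the first step between compounds that differ in one place: in this assay, the change from 3-methylphenyl to 3-methoxyphenyl gives a 1.2-fold lower number from compound 1 to compound 4 (0.09 log units; within the scatter). Going by these compounds alone, on this aromatic carbon, meta to a large group, methoxy in place of methyl therefore leaves the read-out within the scatter, even though an oxygen and a hydrogen-bond acceptor enter with it, something the earlier compounds, which differ from one another in more than one place, could not show. No measurement here bears on why the two groups read alike, so the step stands without an explanation.

From the compounds shown here alone, what remains open is whether this position stays as insensitive to groups of a different kind, such as an amine, a carboxylic acid or a longer chain like ethoxy in place of methyl on the same aromatic carbon. Going by these compounds, it is also open whether methoxy in place of methyl reads the same at another place on this ring, since a single step at one place says nothing about the others.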